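The source may report more compounds than this note shows. Statements on the series, on what has been measured and on what is new or still open speak of the compounds shown alone.

Working notes on the series, read in a functional assay on NUGC-3 cells (Homo sapiens) for antiproliferative activity, read by sulforhodamine B assay; a higher number here means a weaker inhibitor of growth, a lower number a stronger inhibitor of growth. Compound 1 `CCCCCCOc1cccc(O)c1C(=O)/C=C/c1ccc(O)cc1` gives > 30000 nM, which is a limit of the assay and not a number. Within the data shown here, compound 2 `O=C(/C=C/c1ccc(O)cc1)c1c(O)cccc1OCC1CCCC1` gives 2140 nM, the only actual number so far. Compound 3 `CC(C)COc1cccc(O)c1C(=O)/C=C/c1ccc(O)cc1` differs from compound 2 by isopropyl in place of cyclopentyl on a saturated chain carbon bound to an oxygen on an aromatic ring. Among the measured compounds shown here, one measured step bears on this place: an at least 14-fold lower number from compound 1 to compound 2 (1.14 log units; beyond the scatter), large and beyond the scatter, with cyclopentyl replacing pentyl. Compound 3 gives up the ring of compound 2 but stays branched, so part of that gain is expected to be lost, though this rests on a single step. The expected change is a 2.8-fold higher number from compound 2 to compound 3 (0.45 log units; beyond the scatter), a moderate move towards weaker growth inhibition. For compound 3 the estimated value is 6000 nM, with an expected range of 2000 nM to 25000 nM.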

Compound 3, concentration for 50% growth inhibition: 2980 nM
For compound 3 the middle estimate is 2.0-fold (0.30 log units) above the measured one; low and high end bracket the measured number.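

In this assay, the ring of compound 2 is not required at this position: isopropyl in place of cyclopentyl gives a 1.4-fold higher number from compound 2 to compound 3 (0.14 log units; within the scatter), so branching without a ring holds the level of growth inhibition seen with cyclopentyl. Isopropyl in place of pentyl gives an at least 10-fold lower number from compound 1 to compound 3 (1.00 log units; beyond the scatter), which leaves compound 1, with its unbranched chain, apart from the other two compounds. Compound 1 stands at a limit of the assay and not at a number, so this step and the earlier one from pentyl have no defined upper size: the limit of > 30000 nM in this assay, at which 1 of the 3 values shown sits.

Pentyl differs from both other groups in length as well as in branching, and the compounds shown do not separate the two. On these data alone, whether a shorter straight chain such as propyl, a cyclohexyl or a terminal amine would hold this level remains open.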